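Adding a Methyl Group to Compound 3

The compounds below may be only part of what the source reports. "The series", "measured", "known", "first", "only" and "open" are said of these compounds alone.

In a functional assay on DU-145 cells (Homo sapiens) for inhibition, read by CCK-8 assay, with a stated time of 72 h (a lower number here means a stronger inhibitor, a higher number a weaker inhibitor), compound 1 (`O=C(/C=C/c1cccnc1)NCCCc1ccc(S(=O)(=O)Nc2ccccc2)cc1`) gives > 10000 nM as a limit of the assay and not a number. In this assay, among the compounds with values here, compound 2 (`O=C(/C=C/c1cccnc1)NCCCCCc1cccc(S(=O)(=O)Nc2ccccc2)c1`) gives 140 nM and compound 3 (`O=C(/C=C/c1cccnc1)NCCCCCCc1cccc(S(=O)(=O)Nc2ccccc2)c1`) gives 6.73 nM as the lowest number so far. Compound 4 (`Cc1ccccc1NS(=O)(=O)c1cccc(CCCCCCNC(=O)/C=C/c2cccnc2)c1`) differs from compound 3 by methyl in place of hydrogen on an aromatic carbon, ortho to a large group (methyl in place of hydrogen on an aromatic carbon). This turns phenyl into 2-methylphenyl. Within the data shown here, the compounds measured so far include no such change, so only a modest loss of strength is expected in this assay. The estimate is a step (a 2.1-fold higher number from compound 3 to compound 4 (0.32 log units; beyond the scatter)) toward a higher number. Compound 4 is expected to give 14 nM (estimated range 3 nM to 70 nM) when measured.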

Compound 4, half-maximal inhibitory concentration: 2.9 nM
The estimate for compound 4 lay 4.8-fold (0.68 log units) above the measured number; the whole stated range lies above it.
By their numbers in this assay, from the lowest: compound 4; then compound 3; then compound 2. At a limit, above all of these: compound 1.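

In this assay, turning phenyl into 2-methylphenyl gives a 2.3-fold lower number from compound 3 to compound 4 (0.37 log units; beyond the scatter). Within the data shown here, all the earlier compounds carry a plain phenyl here, so this is the first sign that this ring can take a methyl group ortho to a large group without a loss of strength, and that a single added carbon on it can shift the number beyond the scatter. Nothing measured here explains why the step runs in this direction. Still open, on these data alone, is whether an ethyl group or a methoxy group at this place would lower the number further, and whether methyl on another carbon of this ring would do the same.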